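A few compounds are considered here, and "the series" means these few. Any claim that something is new, unique, unknown or untested is made for them only; others in the source may bear on it.

Three compounds of the series carry a sulfonyl bridge to a substituted phenyl ring on the shared core. Compound 1 `Cc1ccc(S(=O)(=O)c2n[nH]c3ccc(N4CCN(C)CC4)cc23)cc1` gives 4.9 nM in an assay on HeLa cells for displacement of a labelled ligand from 5-hydroxytryptamine receptor 6 (Homo sapiens); a higher number here means a weaker inhibitor, a lower number a stronger inhibitor. Compound 2 `CN1CCN(c2ccc3c(c2)c(S(=O)(=O)c2cccc4ccccc24)nn3Cc2ccccc2)CC1` gives 2 nM in this assay. Compound 3 `CN1CCN(c2ccc3[nH]nc(S(=O)(=O)c4ccccc4Cl)c3c2)CC1` gives 4 nM in this assay, which places compound 3 second highest of the three numbers, closest to compound 1 and furthest from compound 2, with both gaps inside the usual scatter.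

For the measured compounds named here, the one measured step that changes only the aryl group on the sulfonyl sulfur, a 1.2-fold lower number from compound 1 to compound 3 (0.09 log units; within the scatter), shows no shift beyond the scatter. Compound 4 `COc1cccc(S(=O)(=O)c2n[nH]c3ccc(N4CCN(C)CC4)cc23)c1` is not yet measured; it differs from compound 3 in that (3-methoxyphenyl in place of 2-chlorophenyl on a sulfonyl sulfur). Going by the values given here, the only comparable step bears on this one and was flat, so the change from compound 3 to compound 4 is expected to stay within the scatter, with an estimated step of a 1.3-fold higher number from compound 3 to compound 4 (0.10 log units; within the scatter) in this assay. For compound 4 the estimate in this assay is 5 nM, with a range from 2 nM to 15 nM.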

Compound 4, inhibition constant: 1.1 nM
Estimate against measurement, compound 4: 4.5-fold (0.66 log units) above, outside the stated range (below it).
By their numbers in this assay, from the lowest: compounds 4, 2, 3 and 1 (each within the scatter of the next, the first and the last beyond it).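

The aryl group on the sulfonyl sulfur can move the number in this assay beyond the scatter, as the changes to 3-methoxyphenyl show with a 3.6-fold lower number from compound 3 to compound 4 (0.56 log units; beyond the scatter) and a 4.5-fold lower number from compound 1 to compound 4 (0.65 log units; beyond the scatter). The earlier step between 4-methylphenyl and 2-chlorophenyl was flat, so among these three groups only 3-methoxyphenyl stands apart from the other two, while compound 2 differs in more than one place and stays out of this comparison. Nothing among the data shown bears on what lies behind this shift.

From the compounds shown here alone, it remains open whether the lower number belongs to the methoxy group itself or to its place on the phenyl ring. Going by these compounds, it is also open whether an ethoxy group or an amine in place of the methoxy group would keep the number this low.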